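From Bromo to Acetyl: Expecting a Weaker Inhibitor

The source may report more compounds than this note shows. Statements on the series, on what has been measured and on what is new or still open speak of the compounds shown alone.

Of the compounds shown here, three built on one shared core have been tested in an assay on isolated protein for inhibition of Indoleamine 2,3-dioxygenase 1 (Homo sapiens), read by spectrophotometry; a lower number here means a stronger inhibitor, a higher number a weaker inhibitor. Compound 1 `O/N=C(/Nc1cccc(F)c1)c1ccc2occc2c1` gives 32700 nM, compound 2 `O/N=C(/Nc1cccc(Cl)c1)c1ccc2occc2c1` gives 690 nM, and compound 3 `O/N=C(/Nc1cccc(Br)c1)c1ccc2occc2c1` gives 440 nM, standing at the low end of the three numbers, with its gap to compound 2 lying within the scatter while a 74-fold lower number from compound 1 to compound 3 (1.87 log units; beyond the scatter). Compound 4 `CC(=O)c1cccc(N/C(=N/O)c2ccc3occc3c2)c1` differs from compound 3 by acetyl in place of bromo on an aromatic carbon. The measured steps concern halogens only: a 47-fold lower number from compound 1 to compound 2 (1.68 log units; beyond the scatter) and a 1.6-fold lower number from compound 2 to compound 3 (0.20 log units; within the scatter). Among the compounds with values here, no measured step involves acetyl, so the comparison rests on the halogen steps alone, which show that exchanges at this place can move the number a great deal. A moderate loss is expected, a 3.4-fold higher number from compound 3 to compound 4 (0.53 log units; beyond the scatter). Compound 4 is therefore estimated at 1500 nM, with a range from 300 nM to 8000 nM.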

Compound 4, half-maximal inhibitory concentration: > 30000 nM
Compound 4: no number, only a limit (the forecaster's own chance of this, stated with the estimate: 5%); middle value at least 20-fold (1.30 log units) from the limit.
By their numbers in this assay, from the lowest: compounds 3 and 2 (each within the scatter of the next); then compound 1.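

Compound 4 has only a limit, not a number: the limit of > 30000 nM in this assay, at which 1 of the 4 values shown sits. Even so, both readable steps are large, an at least 68-fold higher number from compound 3 to compound 4 (1.83 log units; beyond the scatter) and an at least 43-fold higher number from compound 2 to compound 4 (1.63 log units; beyond the scatter), so at this place on the aromatic ring, acetyl does not keep what chloro and bromo reach. The step between compound 1 and compound 4 cannot be read, so those two cannot be ranked.

From the compounds shown here alone, whether the loss follows the carbonyl or the extra heavy atoms of acetyl stays open. An ethyl or an amine at this place would speak to that.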